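Working notes: aminophenyl to dichlorophenyl exchange at the carbonyl

The source may report more compounds than this note shows. Statements on the series, on what has been measured and on what is new or still open speak of the compounds shown alone.

Of the compounds shown here, two have numbers so far, compound 1 `COc1ccc(-c2cc(/C=C/C(=O)c3ccc(N)cc3)[nH]n2)cc1` and compound 2 `COc1cc(-c2cc(/C=C/C(=O)c3ccc(N)cc3)[nH]n2)cc(OC)c1OC`. In a functional assay on NCI-H522 cells (Homo sapiens) for cytotoxicity, read by sulforhodamine B assay, with a stated time of 48 h, tested at 1 uM (a higher number here means a weaker effect of the compound at the concentration tested, a lower number a stronger effect), compound 1 gives 61%, and compound 2 gives 77%. Compound 2 thus stands highest of the two numbers, with compound 1 the nearest, lower by a gap beyond the usual scatter; on these numbers compound 2 shows the weaker effect at the concentration tested. Compound 3 `COc1cc(-c2cc(/C=C/C(=O)c3ccc(Cl)c(Cl)c3)[nH]n2)cc(OC)c1OC` has not yet been measured in this assay. It differs from compound 2 in one place: 3,4-dichlorophenyl in place of 4-aminophenyl on a carbonyl carbon. Among the measured compounds shown here, no measured pair covers a change of this kind, so the data give no guide to its direction. The expected step is a number 7 percentage points lower from compound 2 to compound 3 (within the scatter), within the scatter and without a clear direction. Compound 3 is therefore estimated at 70% in this assay, with a range from 40% to 100%.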

Compound 3, a percentage reported as activity, at one concentration (the size of the read-out at that concentration, not a potency): 67%
Compound 3: the middle estimate sits 3 percentage points above what was measured; the measured number falls inside the stated range.
By their numbers in this assay, from the lowest: compounds 1, 3 and 2 (each within the scatter of the next, the first and the last beyond it).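

In this assay, among the compounds shown here, the first measured change at this position, 3,4-dichlorophenyl in place of 4-aminophenyl on a carbonyl carbon, gives a number 10 percentage points lower from compound 2 to compound 3 (within the scatter). At this single concentration, the read-out therefore does not separate the two groups, even though the exchange removes the nitrogen and brings in two chlorine atoms, so the amino group is not shown to be required for the effect seen with compound 2. Nothing available explains this outcome.

For the compounds shown here, open is whether the same exchange behaves alike on the core of compound 1, which carries one methoxy group on its other aryl ring, since only one pair covers this change. Also open, on these data alone, is how a plain phenyl, a 4-hydroxyphenyl or a 4-chlorophenyl group would read at this position.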